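Stereocentre inversion on the tert-butyl ester enamide

The source may hold more compounds than are shown below. What is called first, only, known or untested is meant among the compounds shown, and "the series" means these compounds.

Working notes on the series. Compound 1 `CCOC(=O)/C=C/NC(=O)[C@H](O)C(C)(C)CO` and compound 2 `CC(C)(C)OC(=O)/C=C/NC(=O)[C@@H](O)C(C)(C)CO` have been run in an ADME assay on WI-38 cells (Homo sapiens) for inhibition, read by CellTiter-Glo, with a stated time of 48 h, tested at 100 uM; on this read-out lower numbers stand for less inhibition and higher numbers for more inhibition at the one concentration tested (going by the name of the read-out). In this assay compound 1 gives 36%, and in this assay compound 2 gives 14%. Among these two numbers compound 2 stands lowest; the nearest number, that of compound 1, lies above it by a gap beyond the usual scatter. Among the measured compounds shown here, the two measured compounds differ in more than one place, so no single-change step between them exists and the gap cannot be assigned to one change.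

Compound 3 `CC(C)(C)OC(=O)/C=C/NC(=O)[C@H](O)C(C)(C)CO` has not yet been measured in this assay. Its relation to compound 2: the two compounds have the same atoms and bonds and differ only in configuration as drawn: 1 of 2 stereo elements differ; a stereocentre at a saturated chain carbon is drawn S in compound 2 and R in compound 3. Compound 1 is drawn with the same configuration at that stereocentre as compound 3 but differs elsewhere, so it does not supply a clean step for this change. With no measured step of this kind in this assay, the expected step is small, most likely within the scatter, leaning slightly upward because compound 1 gives 36%. The expected step from compound 2 to compound 3 is a number 8 percentage points higher from compound 2 to compound 3 (within the scatter). For compound 3 in this assay the estimate is 22%, within a range from 5% to 45%.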

Compound 3, a percentage reported as inhibition, at one concentration (the size of the read-out at that concentration, not a potency): 0%
Compound 3: the middle estimate sits 22 percentage points above what was measured, and the stated range ends above it.
By their numbers in this assay, from the lowest: compound 3; then compound 2; then compound 1.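

The pair gives the first clean reading at the stereocentre on the saturated chain carbon: in this assay, the change from S to R as drawn gives a number 14 percentage points lower from compound 2 to compound 3 (beyond the scatter), and this step can be assigned to configuration alone: the fact that compounds 2 and 3 differ only in the configuration as drawn

With the R configuration held as drawn, tert-butyl in place of ethyl on an oxygen next to a carbonyl group gives a number 36 percentage points lower from compound 1 to compound 3 (beyond the scatter), a step of larger size that supplies the single-change reading for the ester group that the earlier pair lacked. The gap between compound 1 and compound 2, which could not be assigned to one change, can now be followed through compound 3 as one ester step and one configuration step, and both steps lie beyond the scatter.

Whether the configuration step keeps its direction and size with ethyl in place of tert-butyl remains open, since the only configuration pair shown carries the tert-butyl ester. Also open, going by these compounds, is how this assay responds to a carboxylic acid or a longer chain in place of the ester alkyl group, and whether a free amine on the shared core would change the reading.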